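Swapping an imidazole for a triazolylmethyl arm

The compounds below may be only part of what the source reports. "The series", "measured", "known", "first", "only" and "open" are said of these compounds alone.

Compound 1 `CC(C)C(c1ncc[nH]1)c1ccc(-c2ccc3cccc(F)c3c2)[nH]c1=O` was tested in an ADME assay on microsomes from liver (Homo sapiens) for metabolic stability; on this read-out lower numbers stand for a shorter-lived compound and higher numbers for a longer-lived compound. In this assay compound 1 gives < 0.0667 h, which is a limit of the assay rather than a number, so for compound 1 only a limit is known. Compound 2 `CC(C)C(c1ccc(-c2ccc3cccc(F)c3c2)[nH]c1=O)N1CCNC1=O` gives 1.03 h in this assay, and compound 3 `Cc1c[nH]c(C(c2ccc(-c3ccc4cccc(F)c4c3)[nH]c2=O)C(C)C)n1` gives 0.09 h. Two measured steps start from compound 1: an at least 15-fold higher number from compound 1 to compound 2 (1.18 log units; beyond the scatter), and an at least 1.3-fold higher number from compound 1 to compound 3 (0.13 log units; that floor lies within the scatter). Between the other two, an 11-fold lower number from compound 2 to compound 3 (1.06 log units; beyond the scatter).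

Compound 4 `CC(C)C(Cc1nnc[nH]1)c1ccc(-c2ccc3cccc(F)c3c2)[nH]c1=O` has not yet been measured. It differs from compound 1 in one place: (4H-1,2,4-triazol-3-yl)methyl in place of 1H-imidazol-2-yl on a saturated chain carbon bound to an aromatic carbon and a saturated chain carbon. Like compound 4, compound 3 still carries a five-membered aromatic ring with hetero atoms on the saturated chain carbon bound to an aromatic carbon and a saturated chain carbon, and its step from compound 1 was small. The large step to compound 2 came with 2-oxoimidazolidin-1-yl, which compound 4 does not carry. For compound 4 a modest rise is therefore expected, an at least 2.2-fold higher number from compound 1 to compound 4 (0.35 log units; beyond the scatter), with an estimated value of 0.15 h in a range from 0.05 h to 0.45 h.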

Compound 4, half-life: 0.307 h
For compound 4 the middle estimate is 2.0-fold (0.31 log units) below the measured one, and the stated range covers the measured number.
By their numbers in this assay, from the lowest: compound 3; then compound 4; then compound 2. At a limit, below all of these: compound 1.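

Compound 4 shows that an aromatic ring group carried on this saturated chain carbon need not stay as short-lived as the two imidazole compounds: in this assay there is an at least 4.6-fold higher number from compound 1 to compound 4 (0.66 log units; beyond the scatter), and there is also a 3.4-fold higher number from compound 3 to compound 4 (0.53 log units; beyond the scatter). Even so, the new arm does not match the 2-oxoimidazolidin-1-yl group, with a 3.4-fold lower number from compound 2 to compound 4 (0.53 log units; beyond the scatter). The step from compound 1 gives only a floor, because compound 1 stands at a limit of the assay: the limit of < 0.0667 h in this assay, at which 1 of the 4 values shown sits.

On these data alone, whether the rise follows the triazole ring or the methyl link stays open, as the two change together here. A (1H-imidazol-2-yl)methyl arm, or a 4H-1,2,4-triazol-3-yl group set directly on the chain carbon, would separate them.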